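Bile acid receptor binding: aryl swap on the benzyl group

The compounds below may be only part of what the source reports. "The series", "measured", "known", "first", "only" and "open" are said of these compounds alone.

Measured so far in an assay on isolated protein with Bile acid receptor (Homo sapiens) as the target; on this read-out lower numbers stand for an effect already at smaller amounts and higher numbers for an effect only at larger amounts of compound:
Compound 1 `COC(=O)/C=C/c1cccc(N(Cc2ccc(/C=C/c3ccccn3)cc2)C(=O)C2CCCCC2)c1` gives 309 nM.
Compound 2 `COC(=O)/C=C/c1cccc(N(Cc2ccc(/C=C/c3ccccn3)cc2)C(=O)C(C)C)c1` gives 310 nM.
Compound 3 `COC(=O)/C=C/c1cccc(N(Cc2ccc(/C=C/c3cccc(F)c3)cc2)C(=O)NC(C)C)c1` gives 467 nM.

All three numbers lie within the scatter of one another, so no ranking among them is justified. Among the compounds with values here, the one measured step, a 1.0-fold higher number from compound 1 to compound 2 (0.00 log units; within the scatter), sits on the carbonyl carbon, not on the aromatic carbon changed here. Compound 3 carries a different terminal ring but also a different group on the carbonyl, so no single-place comparison to compound 2 exists.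

Compound 4 `COC(=O)/C=C/c1cccc(N(Cc2ccc(-c3ccc(F)c(Cl)c3)cc2)C(=O)C(C)C)c1` differs from compound 2 by 3-chloro-4-fluorophenyl in place of 2-(pyridin-2-yl)ethenyl on an aromatic carbon. Within the data shown here, no measured step bears on this position. Given the flat picture across compounds 1, 2 and 3, compound 4 is expected to give 350 nM, spanning 150 nM to 800 nM, which amounts to an expected 1.1-fold higher number from compound 2 to compound 4 (0.05 log units; within the scatter).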

Compound 4, half-maximal effective concentration: 129 nM
For compound 4 the middle estimate is 2.7-fold (0.43 log units) above the measured one; the measured number lies below the stated range.
By their numbers in this assay, from the lowest: compound 4; then compounds 1, 2 and 3 (each within the scatter of the next).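

In this assay, within the data shown here, this aromatic carbon is the first place where a single change moves the number beyond the scatter: 3-chloro-4-fluorophenyl in place of 2-(pyridin-2-yl)ethenyl gives a 2.4-fold lower number from compound 2 to compound 4 (0.38 log units; beyond the scatter) whereas the change on the carbonyl carbon gave a 1.0-fold higher number from compound 1 to compound 2 (0.00 log units; within the scatter) and stayed within it. The swap removes the ring nitrogen and the double bond together, so the step cannot be assigned to either alone. Nothing available explains the step.

As far as these compounds go, whether the chlorine, the fluorine or the plain phenyl ring carries it remains open. So does the outcome with an amine or a carboxylic acid on the terminal ring.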